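Azocane in place of the six-membered ring on compound 3

A few compounds are considered here, and "the series" means these few. Any claim that something is new, unique, unknown or untested is made for them only; others in the source may bear on it.

Measured compounds:
compound 1 `CC1CCC(Nc2nc(C(F)(F)F)ccc2CNC(=O)C(C)c2ccc(NS(C)(=O)=O)c(F)c2)CC1`: 1130 nM
compound 2 `CC(C(=O)NCc1ccc(C(F)(F)F)nc1NCc1ccccc1)c1ccc(NS(C)(=O)=O)c(F)c1`: 203 nM
compound 3 `CC(C(=O)NCc1ccc(C(F)(F)F)nc1N1CC=CCC1)c1ccc(NS(C)(=O)=O)c(F)c1`: 12.1 nM

In a functional assay on CHO-K1 cells for antagonist activity at transient receptor potential cation channel subfamily V member 1 (Homo sapiens), read by FLIPR (on this read-out lower numbers stand for stronger inhibition and higher numbers for weaker inhibition), compound 3 gives 12.1 nM and stands lowest of the three numbers; compound 2 is the nearest, compound 1 the furthest. Both steps into compound 3 replace a group of 8 heavy atoms on the aromatic carbon by the six-membered ring with one hetero atom: a 93-fold lower number from compound 1 to compound 3 (1.97 log units; beyond the scatter) and a 17-fold lower number from compound 2 to compound 3 (1.22 log units; beyond the scatter). The step of a 5.6-fold lower number from compound 1 to compound 2 (0.75 log units; beyond the scatter) is the smaller of the three.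

Compound 4 `CC(C(=O)NCc1ccc(C(F)(F)F)nc1N1CCCCCCC1)c1ccc(NS(C)(=O)=O)c(F)c1` differs from compound 3 in one place: a group of 8 heavy atoms (7 carbon, 1 nitrogen; one eight-membered non-aromatic ring with 1 hetero atom) in place of a group of 6 heavy atoms (5 carbon, 1 nitrogen; one six-membered non-aromatic ring with 1 hetero atom), on an aromatic carbon. The change goes back to 8 heavy atoms on the same aromatic carbon, which in both measured steps went with a large step toward a higher number, though neither of the groups that entered there was an eight-membered ring with one hetero atom, so the bearing is indirect. A step toward a higher number beyond the scatter is therefore expected, smaller than either measured step because compound 3, with 12.1 nM, shares the nitrogen on that aromatic carbon with compound 4. For compound 4 the expected step is a 3.7-fold higher number from compound 3 to compound 4 (0.57 log units; beyond the scatter). The estimate for compound 4 in this assay is 45 nM, with a range from 12 nM to 200 nM.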

Compound 4, half-maximal inhibitory concentration: 27.8 nM
Estimate against measurement, compound 4: 1.6-fold (0.21 log units) above; measured number inside the range.
By their numbers in this assay, from the lowest: compound 3; then compound 4; then compound 2; then compound 1.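

In this assay, enlarging the ring at this aromatic carbon, next to the ring nitrogen, gives only a 2.3-fold higher number from compound 3 to compound 4 (0.36 log units; beyond the scatter), a modest step that is still beyond the scatter. The earlier compounds shown here linked a group of 8 heavy atoms at this place with large losses, but compound 4 shows that this count alone does not set the number: the eight-membered ring with 1 hetero atom gives a 7.3-fold lower number from compound 2 to compound 4 (0.86 log units; beyond the scatter) against the benzyl compound and a 41-fold lower number from compound 1 to compound 4 (1.61 log units; beyond the scatter) against the 4-methylcyclohexyl compound. Among the four compounds, the two with the nitrogen inside the ring, compound 3 and compound 4, stand lowest, and compound 1 and compound 2, with that nitrogen outside a ring, stand highest, with no compound going against this split.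

No accompanying measurement accounts for these differences. The step into compound 4 enlarges the ring and removes the double bond together, so the two changes cannot be separated here; a saturated piperidine or an azepane at this place would begin to pull them apart.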